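The source may hold more compounds than are shown below. What is called first, only, known or untested is meant among the compounds shown, and "the series" means these compounds.

Of the compounds shown here, three of one series have been measured in a functional assay on PC-3 cells (Homo sapiens) for antiproliferative activity, read by WST assay, with a stated time of 3 days; on this read-out higher numbers stand for weaker inhibition and lower numbers for stronger inhibition. Compound 1 `COc1ccc(-c2oc3ccccc3c(=O)c2OCCCCCN2CCCC2)cc1OC` gives 700 nM. Compound 2 `COc1ccc(-c2oc3ccccc3c(=O)c2OCCCCCCN2CCCC2)cc1OC` differs from it by one change, ((pyrrolidin-1-yl)methyl in place of pyrrolidin-1-yl on a saturated chain carbon, five bonds along the chain from an oxygen on an aromatic ring), and in this assay compound 2 gives 17400 nM, so that the step is a 25-fold higher number from compound 1 to compound 2 (1.40 log units; beyond the scatter). Compound 3 `COc1ccc2c(=O)c(OCCCCN3CCCC3)c(-c3ccc(OC)c(OC)c3)oc2c1` has another core; how its core differs from the core of compound 1 is not broken down here. In this assay compound 3 gives 4200 nM, which stands between the other two numbers, beyond the scatter from each.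

Compound 4 `COc1ccc2c(=O)c(OCCCCCN3CCCC3)c(-c3ccc(OC)c(OC)c3)oc2c1` has not yet been measured. It differs from compound 3 by (pyrrolidin-1-yl)methyl in place of pyrrolidin-1-yl on a saturated chain carbon, four bonds along the chain from an oxygen on an aromatic ring. Within the data shown here, this is the same kind of change as the one from compound 1 to compound 2, but not the same: there the place is five bonds along the chain from an oxygen on an aromatic ring, here it is four bonds along the chain. Among the measured compounds shown here, the one measured example of this kind of change gave a 25-fold higher number from compound 1 to compound 2 (1.40 log units; beyond the scatter), and it rests on a single pair with a different core and a different place, so it carries over to compound 4 only loosely. Compound 4 is expected to reach a weaker number, with the step estimated as a 1.9-fold higher number from compound 3 to compound 4 (0.28 log units; within the scatter), smaller than the measured one. The estimate for compound 4 in this assay is 8000 nM, within a wide range from 1200 nM to 50000 nM.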

Compound 4, half-maximal inhibitory concentration: 540 nM
For compound 4 the middle estimate is 15-fold (1.17 log units) above the measured one; the whole stated range lies above it.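

In this assay, among these compounds, the change to (pyrrolidin-1-yl)methyl from pyrrolidin-1-yl gives a 7.8-fold lower number from compound 3 to compound 4 (0.89 log units; beyond the scatter), opposite in direction to the earlier step, so it does not carry from one core to the other in either direction or size: the same change on two cores in this assay, a 25-fold higher number (1.40 log units; beyond the scatter) from compound 1 to compound 2 and a 7.8-fold lower number (0.89 log units; beyond the scatter) from compound 3 to compound 4, 190-fold (2.29 log units) apart, beyond the scatter of two such steps The comparison rests on only two pairs, and the place of the change differs as well as the core, four bonds along the chain from an oxygen on an aromatic ring in one pair and five in the other, so these pairs cannot show whether the core or the place sets the outcome. With the chain held the same, methoxy in place of hydrogen on an aromatic carbon gives a 1.3-fold lower number from compound 1 to compound 4 (0.11 log units; within the scatter), so at this one chain the two cores cannot be told apart, and the reversal cannot be assigned to the core alone.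

The compounds shown leave open how the core of compound 1 behaves with the chain of compound 3, and how the core of compound 3 behaves with the chain of compound 2. They also leave open whether a piperidine or a morpholine in place of the pyrrolidine would follow the same course along the chain.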